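The source may hold more compounds than are shown below. What is called first, only, known or untested is meant among the compounds shown, and "the series" means these compounds.

Two compounds of the series have numbers in a functional assay for antagonist activity at thyroid hormone receptor beta (Homo sapiens), read by fluorescence polarization, with a stated time of 3 h; a higher number here means a weaker inhibitor, a lower number a stronger inhibitor. Compound 1 `CN(Cc1cccc(F)c1)C(=O)c1sc(-c2ccc(S(C)(=O)=O)c([N+](=O)[O-])c2)nc1C(F)(F)F` gives 2800 nM; compound 2 `CC1CCN(C(=O)c2sc(-c3ccc(S(C)(=O)=O)c([N+](=O)[O-])c3)nc2C(F)(F)F)CC1` gives 310 nM, the lower of the two, the step of a 9.0-fold lower number from compound 1 to compound 2 (0.96 log units; beyond the scatter) coming from the group on the carbonyl carbon alone. Compound 3 `Cc1nc(-c2ccc(S(C)(=O)=O)c([N+](=O)[O-])c2)sc1C(=O)N1CCC(C)CC1` differs from compound 2 elsewhere: methyl in place of trifluoromethyl on an aromatic carbon. No measured step touches this position, so nothing measured bears on it and no direction is indicated by the data shown. The expectation for compound 3 in this assay is a change of about a 1.5-fold higher number from compound 2 to compound 3 (0.16 log units; within the scatter), within the scatter, with wide uncertainty. Compound 3 is therefore estimated at 450 nM, range 120 nM to 1800 nM.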

Compound 3, half-maximal inhibitory concentration: 7400 nM
The estimate for compound 3 lay 16-fold (1.22 log units) below the measured number, outside the stated range (above it).
By their numbers in this assay, from the lowest: compound 2; then compound 1; then compound 3.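

With the (4-methylpiperidin-1-yl)carbonyl group held fixed, the aromatic carbon next to the ring nitrogen proves sensitive in this assay: methyl in place of trifluoromethyl gives a 24-fold higher number from compound 2 to compound 3 (1.38 log units; beyond the scatter). Of these two groups, trifluoromethyl gives the stronger inhibitor at this position. Nothing available explains the loss.

The compounds shown leave open how ethyl, chlorine or a nitrile on this carbon would read. They also leave open whether the same change carries over when the carbonyl bears the (3-fluorobenzyl)(methyl)amino group.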